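Swapping Iodo for Ethyl on the Shared Core

The source may hold more compounds than are shown below. What is called first, only, known or untested is meant among the compounds shown, and "the series" means these compounds.

Among the compounds with values here, compound 2 `O=C(/C=C/c1ccc2c(c1)B(O)OC2)c1ccc(I)cc1` gives 14900 nM in a functional assay on MDA-MB-231 cells (Homo sapiens) for cytotoxicity, read by MTT assay, with a stated time of 48 h (on this read-out higher numbers stand for weaker inhibition and lower numbers for stronger inhibition), the highest of the two numbers measured so far. Its nearest neighbour, compound 1 `O=C(/C=C/c1ccc2c(c1)B(O)OC2)c1ccc(Cl)cc1`, gives 7900 nM in this assay, and the step of a 1.9-fold higher number from compound 1 to compound 2 (0.28 log units; within the scatter) lies within the scatter. Compound 3 `CCc1ccc(C(=O)/C=C/c2ccc3c(c2)B(O)OC3)cc1` carries ethyl in place of iodo on an aromatic carbon. Within the data shown here, the single measured step, which exchanged one halogen for another on that same aromatic carbon, stayed within the scatter, and nothing else measured bears on this change. For compound 3 the expected step is therefore a 1.2-fold lower number from compound 2 to compound 3 (0.09 log units; within the scatter), nothing beyond the scatter. Compound 3 is estimated at 12000 nM, with a range from 5000 nM to 30000 nM.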

Compound 3, half-maximal inhibitory concentration: 9800 nM
For compound 3 the middle estimate is 1.2-fold (0.09 log units) above the measured one, and the stated range covers the measured number.
By their numbers in this assay, from the lowest: compounds 1, 3 and 2 (each within the scatter of the next).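

Until now, only two halogens had been compared at this place, on an aromatic carbon para to a large group. Ethyl, which holds carbon only, now stands there too, and neither step leaves the scatter in this assay (a 1.5-fold lower number from compound 2 to compound 3 (0.18 log units; within the scatter)) (a 1.2-fold higher number from compound 1 to compound 3 (0.09 log units; within the scatter)). These three compounds therefore cannot be told apart on this read-out, and no measurement on hand offers an explanation. Going by these compounds, whether an amine, a carboxylic acid or a longer chain at this place would give a step beyond the scatter remains open.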